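A few compounds are considered here, and "the series" means these few. Any claim that something is new, unique, unknown or untested is made for them only; others in the source may bear on it.

Three compounds share one core and differ only at the amide-type nitrogen. Compound 1 `CNC(=O)CC1CCc2cc(OC)c(OC)cc21` carries a methylamino group on its carbonyl carbon; in a functional assay on the whole organism (strain Wistar) for inhibition, with Rattus norvegicus as the target, read by paw edema, with stated times of 60 min and 1 h, at a dose of 100 mg/kg by the oral route (on this read-out higher numbers stand for more inhibition at the one dose given (going by the name of the read-out) and lower numbers for less inhibition), compound 1 gives 15.6%. Compound 2 `COc1cc2c(cc1OC)C(CC(=O)N(C)C)CC2` gives 25%, and compound 3 `CCN(CC)C(=O)CC1CCc2cc(OC)c(OC)cc21` gives 31.3%. Compound 1 thus has the lowest of the three numbers: the step of a number 9.4 percentage points higher from compound 1 to compound 2 (within the scatter) lies within the scatter, while the step of a number 15.7 percentage points higher from compound 1 to compound 3 (beyond the scatter) lies beyond it. The step of a number 6.3 percentage points higher from compound 2 to compound 3 (within the scatter) is again within the scatter.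

Compound 4 `COc1cc2c(cc1OC)C(CC(=O)NC1CCCC1)CC2` has not yet been measured. It differs from compound 1 in one place: cyclopentyl in place of methyl on an amide-type nitrogen. Both measured steps that start at compound 1 enlarge the group on the amide-type nitrogen; the one beyond the scatter points upward and the other stays within the scatter. A cyclopentyl group enlarges that position as well, so the expectation is a modest upward step, a number 14.4 percentage points higher from compound 1 to compound 4 (beyond the scatter). Compound 4 is therefore estimated at 30%, with a range from 15% to 45%.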

Compound 4, a percentage reported as inhibition, in the whole organism at one dose (the size of the read-out at that dose, not a potency): 40.6%
Compound 4: middle estimate off by 10.6 percentage points, on the low side; the measured number falls inside the stated range.
By their numbers in this assay, from the lowest: compounds 1, 2, 3 and 4 (each within the scatter of the next, the first and the last beyond it).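

In this assay, the step of a number 25 percentage points higher from compound 1 to compound 4 (beyond the scatter) is the largest seen so far, and it shows that a single ring on the amide-type nitrogen, with the amide hydrogen kept, can lift the number beyond the scatter without a second group on that nitrogen. The step of a number 15.6 percentage points higher from compound 2 to compound 4 (beyond the scatter) also lies beyond the scatter, whereas the step of a number 9.3 percentage points higher from compound 3 to compound 4 (within the scatter) stays within it, so cyclopentylamino and diethylamino cannot be told apart here. No measurement is available that explains these differences.

The compounds shown leave open whether the ring itself matters or only the number of carbons, a question that a straight pentyl chain on the same nitrogen would address. They also leave open what a larger ring, such as cyclohexyl, or an aromatic one, such as phenyl, would do at this position.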